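The source may hold more compounds than are shown below. What is called first, only, known or untested is meant among the compounds shown, and "the series" means these compounds.

The three measured compounds share a core that carries a sulfonamide and a 2-carboxyethyl group. Compound 1 `O=C(O)CCn1cc(Cc2ccc(F)cc2)c2cc(NS(=O)(=O)c3ccc(F)cc3)ccc21` gives 0.479 nM in a functional assay on aorta for antagonist activity at thromboxane A2 receptor (Rattus norvegicus); a higher number here means weaker binding, a lower number tighter binding. Compound 2 `Cc1ccc(S(=O)(=O)Nc2ccc3c(c2)c(Cc2ccc(F)cc2)cn3CCC(=O)O)cc1` gives 0.269 nM in this assay. Compound 3 `O=C(O)CCn1ccc2cc(NS(=O)(=O)c3ccc(Cl)cc3)ccc21` gives 2.75 nM in this assay, the highest of the three numbers; compound 1 lies nearest to it and compound 2 furthest, and both gaps are beyond the scatter.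

Compound 4 `O=C(O)CCn1cc(Cc2ccc(F)cc2)c2cc(NS(=O)(=O)c3ccc(Cl)cc3)ccc21` has not yet been measured in this assay. It differs from compound 3 by 4-fluorobenzyl in place of hydrogen on an aromatic carbon. Going by the values given here, no measured pair differs by this change alone. Among the compounds with values here, the only measured step, a 1.8-fold lower number from compound 1 to compound 2 (0.25 log units; within the scatter), concerns a methyl-for-fluoro exchange on an aromatic carbon and lies within the scatter. Compound 3 and compound 1 differ in more than one place, so their gap cannot be assigned with certainty; still, the small size of a 1.8-fold lower number from compound 1 to compound 2 (0.25 log units; within the scatter) suggests that a change of that kind contributes little, leaving the added group as the likely source of most of the difference between compound 3 and compound 1. The expected step toward a lower number is therefore estimated at about a 6.1-fold lower number from compound 3 to compound 4 (0.79 log units; beyond the scatter). Compound 4 is estimated at 0.45 nM, with a range from 0.15 nM to 1.4 nM.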

Compound 4, dissociation constant: 0.234 nM
Estimate against measurement, compound 4: 1.9-fold (0.28 log units) above, and the stated range covers the measured number.
By their numbers in this assay, from the lowest: compounds 4, 2 and 1 (each within the scatter of the next, the first and the last beyond it); then compound 3.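

Going by these compounds alone, the first single-change reading at this position, on the aromatic carbon two ring bonds from the ring nitrogen, shows that 4-fluorobenzyl in place of hydrogen gives a 12-fold lower number from compound 3 to compound 4 (1.07 log units; beyond the scatter) in this assay; the large gap that compound 3 showed against compound 1 and compound 2 now has a counterpart in a pair differing in one place. With the 4-fluorobenzyl group present, exchanges on an aromatic carbon of the other aryl group give smaller steps: chloro in place of methyl gives a 1.1-fold lower number from compound 2 to compound 4 (0.06 log units; within the scatter), and chloro in place of fluoro gives a 2.0-fold lower number from compound 1 to compound 4 (0.31 log units; beyond the scatter), a modest step and the only one of these two beyond the scatter. Nothing available accounts for the size of the step brought by the added group.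

The compounds shown leave open whether the fluorine of this group matters, since they do not compare it with an unsubstituted benzyl, a methyl group, an amine or a longer chain at the same carbon. They also leave open whether the chloro-for-fluoro step would hold with hydrogen at this carbon, and how an amide in place of the carboxylic acid would read.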